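Dropping a benzyl from the nitrogen: an unreadable start

The compounds below may be only part of what the source reports. "The series", "measured", "known", "first", "only" and "open" are said of these compounds alone.

Measured so far:
Compound 1 `COc1ccc(N(Cc2ccc([N+](=O)[O-])cc2)Cc2ccccc2OC)cc1` gives in a functional assay on L929 cells (Mus musculus) for inhibition, read by MTT assay, with a stated time of 5 days (on this read-out higher numbers stand for weaker inhibition and lower numbers for stronger inhibition), only the limit > 40 ug/mL.
Compound 2 `COc1ccc(N(Cc2ccccc2)Cc2ccccc2OC)cc1` gives in this assay only the limit > 40 ug/mL.

Neither of these is a number; both are limits of this assay, as the limit of > 40 ug/mL in this assay, at which 2 of the 2 values shown sit, shows. Among the compounds with values here, the one measured step, a step that the two limits leave unreadable from compound 1 to compound 2, is therefore of unknown size. Compound 2 thus stands at the limit, with no number to anchor it. Compound 3 `COc1ccc(NCc2ccccc2OC)cc1` differs from compound 2 by hydrogen in place of benzyl on a nitrogen on an aromatic ring, so that nitrogen now carries a hydrogen where it carried the benzyl. Within the data shown here, no measured step bears on this change: the only step recorded swapped a nitro for hydrogen elsewhere in the molecule, and even that step could not be read. With nothing pointing either way, the expectation for compound 3 in this assay is a result again at or near the limit, and the step of a number no higher from compound 2 to compound 3 (the limit leaves the size open) is estimated as none beyond the scatter. Compound 3 is estimated at 40 ug/mL, between 20 ug/mL and 80 ug/mL.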

Compound 3, half-maximal inhibitory concentration: 25 ug/mL
Compound 3: the middle estimate sits 1.6-fold (0.20 log units) above what was measured, and the stated range covers the measured number.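

Within the data shown here, compound 3 is the first compound here to give a number rather than a limit in this assay, so replacing the benzyl on the nitrogen with a hydrogen brings the result within what the assay can read. This change gives an at least 1.6-fold lower number from compound 2 to compound 3 (0.20 log units; that floor lies within the scatter), and although the true step could be larger, that floor alone does not go beyond the usual scatter. Its size stays open because one end of the step is not a number: the limit of > 40 ug/mL in this assay, at which 2 of the 3 values shown sit.

Going by these compounds, the step from compound 1 to compound 2 cannot be read, so any effect of the nitro group also remains unknown. On these data alone, it is also open whether a methyl, an acetyl or a longer chain on that nitrogen would give a number like that of compound 3, or whether the nitrogen needs its hydrogen.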